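Fluorine on the fused ring of compound 2

This account rests on a few compounds, and the source may have more. Where it says the series, first, only, none or still open, it means among the compounds named here.

In a functional assay on NCI-H460 cells (Homo sapiens) for cytotoxicity, read by MTT assay, with a stated time of 72 h (on this read-out lower numbers stand for stronger inhibition and higher numbers for weaker inhibition), compound 2 `COc1cc2c(Oc3ccc(NC(=O)c4cc(-c5ccc(C)cc5)nc5ccccc45)cc3F)ccnc2cc1OCCCN1CCC(C)CC1` gives 880 nM, the higher of the two numbers recorded, while compound 1 `COc1cc2c(Oc3ccc(NC(=O)c4cc(-c5cccc(Cl)c5)nc5ccccc45)cc3F)ccnc2cc1OCCCN1CCC(C)CC1` gives 65 nM. Going by the values given here, the only measured step, a 14-fold higher number from compound 1 to compound 2 (1.13 log units; beyond the scatter), concerns the exchange of 3-chlorophenyl for 4-methylphenyl and not the fused ring. Compound 3 `COc1cc2c(Oc3ccc(NC(=O)c4cc(-c5ccc(C)cc5)nc5ccc(F)cc45)cc3F)ccnc2cc1OCCCN1CCC(C)CC1` differs from compound 2 by fluoro in place of hydrogen on an aromatic carbon. Among the compounds with values here, no measured step bears on this change. The expected step of a 1.1-fold lower number from compound 2 to compound 3 (0.04 log units; within the scatter) is therefore none beyond the scatter. Compound 3 is accordingly estimated at 800 nM, with a range from 300 nM to 2500 nM.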

Compound 3, half-maximal inhibitory concentration: 480 nM
The estimate for compound 3 lay 1.7-fold (0.22 log units) above the measured number; measured number inside the range.
By their numbers in this assay, from the lowest: compound 1; then compounds 3 and 2 (each within the scatter of the next).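

In this assay the exchange of hydrogen for fluoro on an aromatic carbon of the fused system of two rings gives a 1.8-fold lower number from compound 2 to compound 3 (0.26 log units; within the scatter) and stays within the scatter. With the 4-methylphenyl group in place, this position thus accepts fluoro without a change that can be read from the numbers. No supporting measurement bears on this result.

As far as these compounds go, what a chloro group, a methoxy group or an amine would do at this carbon remains open. From the compounds shown here alone, it is also open whether fluoro here would behave alike alongside the 3-chlorophenyl group of compound 1.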